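Thiophene for Furan on a Shared Nucleoside Core

A few compounds are considered here, and "the series" means these few. Any claim that something is new, unique, unknown or untested is made for them only; others in the source may bear on it.

Measured so far:
compound 1, `Cc1nc(N)c2c(-c3ccco3)cn([C@@H]3O[C@H](CO)[C@@H](O)[C@H]3O)c2n1` — in a functional assay on CCRF-CEM cells (Homo sapiens), read by MTT assay, with a stated time of 72 h (a lower number here means a stronger inhibitor, a higher number a weaker inhibitor), compound 1 gives > 100000 nM, a limit of the assay.
compound 2, `COc1nc(N)nc2c1c(-c1ccoc1)cn2[C@@H]1O[C@H](CO)[C@@H](O)[C@H]1O` — in this assay compound 2 gives > 20000 nM, also a limit.

Neither value is a number. Compound 1 stands at the limit (the limit of > 100000 nM in this assay, at which 1 of the 2 values shown sits), so its true potency is not known beyond the fact that no inhibition was reached there. Compound 2 sits at the other limit, (the limit of > 20000 nM in this assay, at which 1 of the 2 values shown sits), and its value tells no more than that. Going by the values given here, with no measured pair differing in one place, nothing quantifies how a change on this core moves the read-out.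

Compound 3, `Cc1nc(N)c2c(-c3ccsc3)cn([C@@H]3O[C@H](CO)[C@@H](O)[C@H]3O)c2n1`, differs from compound 1 in one way: thiophen-3-yl in place of furan-2-yl on an aromatic carbon. Since compound 1 itself shows no measurable inhibition, the step of a number no higher from compound 1 to compound 3 (the limit leaves the size open) is expected to be none beyond the usual scatter, with a real chance that compound 3 again reports only a limit. In this assay compound 3 is therefore estimated at 100000 nM, in a range from 20000 nM to 300000 nM.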

Compound 3, half-maximal inhibitory concentration: > 20000 nM
Compound 3: only a limit was reported; the forecaster's own chance of this, stated with the estimate: 70%; the middle value lies beyond the limit too.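

In this assay compound 3 gives > 20000 nM, a limit of the assay. Compound 1 is also known only as a limit, so no step can be read between compound 1 and compound 3. The compounds shown leave open whether thiophen-3-yl in place of furan-2-yl moves the read-out on the shared core at all.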